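Adding a Methoxy Group to Compound 1

This account rests on a few compounds, and the source may have more. Where it says the series, first, only, none or still open, it means among the compounds named here.

Measured compounds:
compound 1 `COc1cc(/C=C/C(=O)c2cccc(-n3cc(-c4ccccc4)[nH]c3=O)c2)ccc1O`: 1910 nM
compound 2 `O=C(/C=C/c1cccc(O)c1)c1cccc(-n2cc(-c3ccccc3)[nH]c2=O)c1`: 1980 nM

In a functional assay on SF-539 cells (Homo sapiens) for inhibition (on this read-out lower numbers stand for stronger inhibition of growth and higher numbers for weaker inhibition of growth), compound 1 gives the lowest of the two numbers, but compound 2 sits within the scatter of it, so the two cannot be told apart. Compound 3 `COc1ccc(-c2cn(-c3cccc(C(=O)/C=C/c4ccc(O)c(OC)c4)c3)c(=O)[nH]2)cc1` differs from compound 1 by methoxy in place of hydrogen on an aromatic carbon, that is, para to a large group on the ring that hangs from the shared core. Among the measured compounds shown here, the single measured step, a 1.0-fold higher number from compound 1 to compound 2 (0.02 log units; within the scatter), changed the other end of the molecule, the aryl on the double-bonded chain, and left the number where it was. For the measured compounds named here, no measured step touches the place that changes in compound 3. With nothing pointing either way, the step from compound 1 to compound 3 is expected to stay within the scatter, a 1.0-fold lower number from compound 1 to compound 3 (0.00 log units; within the scatter). Compound 3 is therefore estimated at 1900 nM, with a range from 700 nM to 5200 nM.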

Compound 3, concentration for 50% growth inhibition: 2250 nM
For compound 3 the middle estimate is 1.2-fold (0.07 log units) below the measured one; the range from low to high includes it.
By their numbers in this assay, from the lowest: compounds 1, 2 and 3 (each within the scatter of the next).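

Among the compounds shown here, this is the first measured change on the phenyl group attached to the shared core. In this assay, methoxy in place of hydrogen, para to a large group, gives a result that cannot be told apart from compound 1 (a 1.2-fold higher number from compound 1 to compound 3 (0.07 log units; within the scatter)), so at this position the added methoxy leaves no readable mark on growth inhibition. No separate measurement is available to explain this result.

A single substituent at a single position is a narrow test, so the flat result cannot be extended to other groups. The compounds shown leave open whether an amine, a carboxylic acid or a longer chain such as butoxy in this same place would also stay within the scatter of compound 1, or would move the number clearly in either direction.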